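Cyclohexyl in place of 4-fluorophenyl on a glycosylated hydrazone

The compounds below may be only part of what the source reports. "The series", "measured", "known", "first", "only" and "open" are said of these compounds alone.

Measured so far:
compound 1, `CCCCC/C=N/NC(=O)c1ccc(O[C@@H]2O[C@H](CO)[C@@H](O)[C@H](O)[C@H]2O)cc1`: 11%
compound 2, `CCCCCc1nnc(-c2ccc(O[C@@H]3O[C@H](COC(C)=O)[C@@H](OC(C)=O)[C@H](OC(C)=O)[C@H]3OC(C)=O)cc2)o1`: 21.5%
compound 3, `O=C(N/N=C/c1ccc(F)cc1)c1ccc(O[C@@H]2O[C@H](CO)[C@@H](O)[C@H](O)[C@H]2O)cc1`: 9.91%

In a functional assay on MDA-MB-231 cells (Homo sapiens) for inhibition, read by MTT assay, with a stated time of 24 h, tested at 100 uM (a lower number here means less inhibition, a higher number more inhibition at the concentration tested (going by the name of the read-out)), compound 3 gives 9.91%, the lowest of the three numbers. Compound 1 stands nearest, and the step of a number 1.1 percentage points lower from compound 1 to compound 3 (within the scatter) is within the scatter, so the two are not told apart. For the measured compounds named here, compound 2 stands furthest, and its gap to compound 3 lies beyond the scatter; compound 2 differs from compound 3 in more than one place, so no single step describes it.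

Compound 4, `O=C(N/N=C/C1CCCCC1)c1ccc(O[C@@H]2O[C@H](CO)[C@@H](O)[C@H](O)[C@H]2O)cc1`, is the next compound. It differs from compound 3 in one place: cyclohexyl in place of 4-fluorophenyl on a carbon with a double bond to nitrogen. Going by the values given here, the only measured step at this carbon, a number 1.1 percentage points lower from compound 1 to compound 3 (within the scatter), exchanged one group for another there and left the read-out in this assay within the scatter. On that basis compound 4 is expected to stay close to compound 3, with a step of a number 1.1 percentage points higher from compound 3 to compound 4 (within the scatter) that is not expected to go beyond the scatter. Compound 4 is therefore estimated at 11% in this assay, with a range from 3% to 20%.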

Compound 4, a percentage reported as inhibition, at one concentration (the size of the read-out at that concentration, not a potency): 0.88%
Compound 4: middle estimate off by 10.1 percentage points, on the high side; the whole stated range lies above it.
By their numbers in this assay, from the lowest: compounds 4, 3 and 1 (each within the scatter of the next, the first and the last beyond it); then compound 2.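

In this assay cyclohexyl in place of 4-fluorophenyl on a carbon with a double bond to nitrogen gives a number 9 percentage points lower from compound 3 to compound 4 (within the scatter) and so does not tell the non-aromatic ring from the aromatic one. Cyclohexyl in place of pentyl on the same carbon gives a number 10.1 percentage points lower from compound 1 to compound 4 (beyond the scatter) and is the first step at this position to go beyond the scatter, though only modestly. This is no clean split of rings from chains, since compound 3 also carries a ring and yet a number 1.1 percentage points lower from compound 1 to compound 3 (within the scatter) does not separate it from compound 1. No measurement at hand accounts for the step from pentyl to cyclohexyl. On these data alone, how a morpholine, an amine or a carboxylic acid on this carbon would read in this assay remains open, as does the effect of a chain longer than pentyl.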